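The source may hold more compounds than are shown below. What is called first, only, known or untested is meant among the compounds shown, and "the series" means these compounds.

Compound 1 `Cc1nc2c(OCc3ccccc3)cccn2c1C(C)SCCNc1n[s+]([O-])nc1N` was examined in a functional assay on the whole organism (stomach) with Rattus norvegicus as the target; on this read-out higher numbers stand for an effect only at larger amounts of compound and lower numbers for an effect already at smaller amounts. In this read-out compound 1 gives only a limit of the assay, >> 25 mg/kg, not a measured number. Compound 2 `Cc1nc2ccccn2c1CSCCNc1nsnc1N` likewise gives only a limit in this assay, namely >> 25 mg/kg. Compound 1 therefore stands at the limit of >> 25 mg/kg in this assay, at which 2 of the 2 values shown sit. For the measured compounds named here, no step between measured compounds can be resolved from these figures, so nothing measured tells how large a change of this kind can be.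

Compound 3 `Cc1nc2c(OCc3ccccc3)cccn2c1C(C)SCCNc1nsnc1N` carries a group of 6 heavy atoms (2 carbon, 3 nitrogen, 1 sulfur; one five-membered aromatic ring with 3 hetero atoms) in place of a group of 7 heavy atoms (2 carbon, 3 nitrogen, 1 oxygen, 1 sulfur; one five-membered aromatic ring with 3 hetero atoms), on an amine nitrogen. Going by the values given here, with no measured step to lean on, the expectation for this assay is that the change from compound 1 to compound 3 amounts to nothing beyond the scatter, a step that the limit leaves unreadable from compound 1 to compound 3, because both measured compounds sit at the limit of >> 25 mg/kg in this assay, at which 2 of the 2 values shown sit. Compound 3 is accordingly expected to come out near 30 mg/kg, within a range from 10 mg/kg to 100 mg/kg, and most probably to be reported once more as a limit rather than as a number.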

Compound 3, dose for half-maximal effect: >> 25 mg/kg
Compound 3 gave a limit, no number; the forecaster's own chance of this, stated with the estimate: 75%; the middle value does not contradict the limit.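

Compound 1 and compound 3 both give only a limit in this assay, so no step between them can be read: the limit of >> 25 mg/kg in this assay, at which 3 of the 3 values shown sit.

The compounds shown leave open what dose of any of them gives a half-maximal effect, and whether the group on the amine nitrogen changes that dose at all.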